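Swapping Acetamido for Dimethylamino on a Shared Core

The source may report more compounds than this note shows. Statements on the series, on what has been measured and on what is new or still open speak of the compounds shown alone.

Compound 3 `CC(=O)Nc1c(C)nc2c(OCc3ccccc3)cccn12` stands second highest of the three numbers measured in a functional assay on the whole organism with Canis familiaris (Canis lupus familiaris) as the target, at a dose of 8 mg/kg by the oral route (on this read-out higher numbers stand for a stronger effect at the one dose given and lower numbers for a weaker effect), where compound 3 gives 44%. Its nearest neighbour is compound 2 `Cc1nc2c(CCc3ccccc3)cccn2c1N`, which gives 52%, a difference within the scatter; furthest is compound 1 `CC(C)c1nc2c(OCc3ccccc3)cccn2c1N`, which gives 0%, a gap beyond the scatter. Compound 4 `Cc1nc2c(OCc3ccccc3)cccn2c1N(C)C` has not yet been measured. It differs from compound 3 in one place: dimethylamino in place of acetamido on an aromatic carbon. Among the measured compounds shown here, no pair of measured compounds differs in just one place, so no single step of this kind has been seen, and nothing here shows what such a change does. I expect the step of a number 6 percentage points lower from compound 3 to compound 4 (within the scatter) in this assay to stay within the scatter, with no clear direction. Compound 4 is therefore estimated at 38%, with a range from 8% to 68%.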

Compound 4, a percentage reported as inhibition, in the whole organism at one dose (the size of the read-out at that dose, not a potency): 72%
Compound 4: the middle estimate sits 34 percentage points below what was measured; measured number outside the range, above it.
By their numbers in this assay, from the lowest: compound 1; then compounds 3 and 2 (each within the scatter of the next); then compound 4.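

Putting dimethylamino in place of acetamido on this aromatic carbon gives a number 28 percentage points higher from compound 3 to compound 4 (beyond the scatter) in this assay. Among the compounds shown here, this is the first single change seen, and it shows that the group at this position can shift the effect at this dose. The change removes the carbonyl and the hydrogen-bond donor of acetamido, but no measurement on hand explains the rise.

Going by these compounds, it remains open whether that donor matters or the group as a whole does. Methylamino, which keeps one hydrogen on the nitrogen, and the larger diethylamino could help separate the two at this position.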